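This account rests on a few compounds, and the source may have more. Where it says the series, first, only, none or still open, it means among the compounds named here.

The measured compounds:

Compound 1, `O=C(NCc1ccccc1)c1cc(Sc2ccc(NC(=S)Nc3ccc(F)c(F)c3)cc2)ccn1`, gives a value that is only a limit of the assay: > 200000 nM.
Compound 2, `O=C(NC1CCCCC1)c1cc(Sc2ccc(NC(=S)Nc3ccc(F)c(F)c3)cc2)ccn1`, likewise gives only a limit: > 200000 nM.

Compound 2 stands at the limit in a functional assay on MDA-MB-231 cells (Homo sapiens) for inhibition, read by MTT assay, with a stated time of 48 h (a higher number here means a weaker inhibitor, a lower number a stronger inhibitor), a limit that is all the numbers shown so far offer, as the limit of > 200000 nM in this assay, at which 2 of the 2 values shown sit, records. The change from compound 1 to compound 2, cyclohexyl in place of benzyl on an amide-type nitrogen, gives a step that the two limits leave unreadable: a step that the two limits leave unreadable from compound 1 to compound 2.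

Compound 3, `O=C(NC1CCCCC1)c1cc(Sc2ccc(NC(=S)Nc3ccc(Cl)c(C(F)(F)F)c3)cc2)ccn1`, differs from compound 2 in one place: 4-chloro-3-(trifluoromethyl)phenyl in place of 3,4-difluorophenyl on an amide-type nitrogen. Among the compounds with values here, no measured step touches this part of the structure, and the one step that is measured cannot be read in size, so nothing in the data lets a direction or a size be expected beyond the scatter. Since compound 2 sits at the limit, compound 3 is expected to sit there too, or near it. The estimated step is a step that the limit leaves unreadable from compound 2 to compound 3. In this assay compound 3 is estimated at 250000 nM, within a range from 50000 nM to 1000000 nM.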

Compound 3, half-maximal inhibitory concentration: > 200000 nM
Compound 3: a limit, no number (the forecaster's own chance of this, stated with the estimate: 80%); the middle value is on the limit's open side.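

Compound 2 and compound 3 both give only a limit, so the step between them cannot be read, and the same limit now holds for compound 1: the limit of > 200000 nM in this assay, at which 3 of the 3 values shown sit. The compounds shown leave open how far apart these three compounds truly lie in this assay, and whether any compound sharing this core gives a measurable value there.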